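Series notes: a repeated ethyl-to-methyl change at the amide side

The source may report more compounds than this note shows. Statements on the series, on what has been measured and on what is new or still open speak of the compounds shown alone.

Compound 1 `CCCn1c(NC(=O)c2ccnn2CC)nc2cc(C(N)=O)cc(OC)c21`, compound 2 `CCCn1c(NC(=O)c2ccnn2C)nc2cc(C(N)=O)cc(OC)c21` and compound 3 `CCn1nccc1C(=O)Nc1nc2cc(C(N)=O)cc(OC)c2n1CCCNC(=O)OCc1ccccc1` have been run in an assay for activation of interferon regulatory factor 3 (Homo sapiens), read by a luciferase reporter, with a stated time of 20 h; on this read-out lower numbers stand for an effect already at smaller amounts and higher numbers for an effect only at larger amounts of compound. Compound 1 gives > 100000 nM, a limit of the assay and not a number. Compound 2 gives > 100000 nM, again a limit. Compound 3 gives > 100000 nM, also a limit. The change from compound 1 to compound 2 is hydrogen in place of methyl on a saturated chain carbon bound to an aromatic nitrogen, and the step is a step that the two limits leave unreadable from compound 1 to compound 2. The cores of compound 1 and compound 3 differ by (benzyloxycarbonyl)amino in place of hydrogen on a saturated chain carbon, three bonds along the chain from an aromatic nitrogen, with the step that the two limits leave unreadable from compound 1 to compound 3. Within the data shown here, every value shown sits at the limit of > 100000 nM in this assay, at which 3 of the 3 values shown sit, so no step among the three is readable.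

Compound 4 `COc1cc(C(N)=O)cc2nc(NC(=O)c3ccnn3C)n(CCCNC(=O)OCc3ccccc3)c12` is not yet measured; it differs from compound 3 by hydrogen in place of methyl on a saturated chain carbon bound to an aromatic nitrogen, the same change as from compound 1 to compound 2, at the same place. The expected step reads a step that the limit leaves unreadable from compound 3 to compound 4, resting on compound 3 at the limit of > 100000 nM in this assay, at which 3 of the 3 values shown sit, and on the unreadable a step that the two limits leave unreadable from compound 1 to compound 2, which gives no sign of a readable number appearing. For compound 4 the expected value in this assay is 150000 nM, estimated between 40000 nM and 1000000 nM, most likely reported again only as a limit.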

Compound 4, half-maximal effective concentration: > 100000 nM
Compound 4 ended at the assay's limit; the forecaster's own chance of this, stated with the estimate: 85%; the middle value is on the limit's open side.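

In this assay compound 4 gives > 100000 nM, a limit of the assay and not a number. The steps from compound 3 and from compound 2 to compound 4 cannot be read, and the series stands at: the limit of > 100000 nM in this assay, at which 4 of the 4 values shown sit.

The compounds shown leave open whether ethyl and methyl on the pyrazole differ at all in this assay, since none gives a readable value.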